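The source may hold more compounds than are shown below. What is called first, only, known or untested is meant among the compounds shown, and "the series" means these compounds.

In a functional assay on DU-145 cells (Homo sapiens) for inhibition, read by trypan blue exclusion, with a stated time of 96 h (on this read-out lower numbers stand for stronger inhibition of growth and higher numbers for weaker inhibition of growth), compound 2 (`COc1cc(OC)c(/C=C(/SCc2ccc(Cl)cc2)C(=O)c2ccc(Br)cc2)c(OC)c1`) gives 1000 nM as the lowest of the numbers shown, while compound 1 (`COc1ccccc1/C=C(\C(=O)c1ccc(Cl)cc1)S(=O)(=O)Cc1ccc(Cl)cc1`) gives 25000 nM there. Compound 3 (`COc1cc(OC)c(/C=C(/SCc2ccc(Cl)cc2)C(=O)c2ccc([N+](=O)[O-])cc2)c(OC)c1`) gives > 100000 nM as a limit and not a number. Compound 4 (`COc1cc(OC)c(/C=C(/SCc2ccc(F)cc2)C(=O)c2ccc(Br)cc2)c(OC)c1`) differs from compound 2 as fluoro in place of chloro on an aromatic carbon with 4-chlorobenzyl turning into 4-fluorobenzyl. Within the data shown here, the one measured step, nitro in place of bromo on an aromatic carbon, is an at least 100-fold higher number from compound 2 to compound 3 (2.00 log units; beyond the scatter) and large, yet it leaves the chloro in place and sets no size for this swap. No step beyond the scatter is therefore expected in this assay for fluoro in place of chloro, with only a slight lean to a higher number. The estimate amounts to a 1.5-fold higher number from compound 2 to compound 4 (0.18 log units; within the scatter) as the expected step. Compound 4 is expected at 1500 nM with an estimated range of 400 nM to 6000 nM for now.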

Compound 4, concentration for 50% growth inhibition: 1000 nM
The estimate for compound 4 lay 1.5-fold (0.18 log units) above the measured number; the measured number falls inside the stated range.
By their numbers in this assay, from the lowest: compounds 2 and 4 (each within the scatter of the next); then compound 1. At a limit, above all of these: compound 3.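

In this assay, 4-fluorobenzyl in place of 4-chlorobenzyl on the sulfanyl arm gives no change at the digits printed from compound 2 to compound 4 (within the scatter). Among these compounds, the earlier step changed the bromo and left this chloro in place, so this is the first reading at this position, and the swap between these two halogens is tolerated with the bromo present. Nothing in hand offers a reason for the flat step.

On these data alone, whether a methoxy, an amine or a carboxylic acid at this position would hold the number stays open. Also open, as far as these compounds go, is whether this position matters at all when the bromo is changed.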